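This account rests on a few compounds, and the source may have more. Where it says the series, first, only, none or still open, it means among the compounds named here.

In a functional assay on HeLa cells (Homo sapiens) for antiproliferative activity, read by MTT assay, with a stated time of 48 h (a higher number here means a weaker inhibitor, a lower number a stronger inhibitor), compound 1 `COc1cc(-c2nnc3c(OC)cc(-c4ccc5[nH]ccc5c4)cn23)cc(OC)c1OC` gives 85 nM. Compound 3 `CCCN1CC(Oc2cc(-c3ccc4c(ccn4C)c3)cn3c(-c4cc(OC)c(OC)c(OC)c4)nnc23)C1`, which also carries a methyl on an aromatic nitrogen but differs elsewhere, gives 211 nM. Compound 2 `COc1cc(-c2nnc3c(OC)cc(-c4ccc5[nH]cc(C=O)c5c4)cn23)cc(OC)c1OC` reads > 10000 nM, which is a limit and not a number; this is the limit of > 10000 nM in this assay, at which 1 of the 3 values shown sits. Compound 4 `COc1cc(-c2nnc3c(OC)cc(-c4ccc5c(c4)c(C=O)cn5C)cn23)cc(OC)c1OC` differs from it by one change, methyl in place of hydrogen on an aromatic nitrogen. Within the data shown here, the only measured step, an at least 110-fold higher number from compound 1 to compound 2 (2.07 log units; beyond the scatter), is large and came with formyl in place of hydrogen on an aromatic carbon. Compound 4 keeps that formyl, so it is expected to stay weak in this assay, with no clear recovery. The expected change is an at least 1.2-fold lower number from compound 2 to compound 4 (0.09 log units; that floor lies within the scatter). Compound 4 is estimated at 8000 nM, within a range of 1500 nM to 20000 nM.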

Compound 4, half-maximal inhibitory concentration: 820 nM
Beside the measured number, compound 4's estimate is 9.8-fold (0.99 log units) above it, outside the stated range (below it).
By their numbers in this assay, from the lowest: compound 1; then compound 3; then compound 4. At a limit, above all of these: compound 2.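

The formyl group on the aromatic carbon does not by itself end activity: with it kept, methyl in place of hydrogen on the aromatic nitrogen, two ring bonds from the ring atom that bears the formyl, gives in this assay an at least 12-fold lower number from compound 2 to compound 4 (1.08 log units; beyond the scatter). This nitrogen therefore matters strongly when the formyl is present. Compound 2 stands at a limit and not at a number, so the size of that step is only a floor: the limit of > 10000 nM in this assay, at which 1 of the 4 values shown sits.

From the compounds shown here alone, whether a longer chain such as propyl on that nitrogen acts like methyl remains open. So does whether an amine in place of the formyl would be tolerated.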